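This account rests on a few compounds, and the source may have more. Where it says the series, first, only, none or still open, it means among the compounds named here.

Among the compounds with values here, compound 1 `Cc1cccc(COc2cccc(/C=C3\C(=O)NN(c4ccccc4)C3=O)c2)c1` gives 5150 nM in a functional assay on cells for agonist activity at Bile acid receptor (Homo sapiens), read by a luciferase reporter (a higher number here means that more compound is needed for the effect, a lower number that less compound is needed), the higher of the two numbers so far, though the gap to compound 2 `O=C1NN(c2ccccc2)C(=O)/C1=C/c1cccc(OCc2cccc(F)c2)c1`, which gives 4790 nM, amounts to a 1.1-fold lower number from compound 1 to compound 2 (0.03 log units; within the scatter), a fluoro in place of methyl on an aromatic carbon. Compound 3 `Cc1cccc(COc2cccc(/C=C3\C(=O)NN(c4ccccc4[N+](=O)[O-])C3=O)c2)c1` differs from compound 1 by nitro in place of hydrogen on an aromatic carbon. Within the data shown here, the one measured step sits on a different part of the shared core and bears on this change only by showing how little a small change on an aromatic carbon has moved this assay. With nothing closer to go on, compound 3 is expected near compound 1, an estimated step of a 1.0-fold lower number from compound 1 to compound 3 (0.01 log units; within the scatter), at 5000 nM, with a range from 1500 nM to 16000 nM.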

Compound 3, half-maximal effective concentration: 5370 nM
The estimate for compound 3 lay 1.1-fold (0.03 log units) below the measured number; low and high end bracket the measured number.
By their numbers in this assay, from the lowest: compounds 2, 1 and 3 (each within the scatter of the next).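

In this assay, within the data shown here, the step is a 1.0-fold higher number from compound 1 to compound 3 (0.02 log units; within the scatter) and gives the first reading at this phenyl, on an aromatic carbon ortho to a large group, whereas the earlier step lay on a different part of the shared core. Phenyl to 2-nitrophenyl adds three heavy atoms here without a change beyond the scatter. No measurement at hand bears on this result. Open, from the compounds shown here alone, is whether an amine or a carboxylic acid on the same aromatic carbon would move the number beyond the scatter. So far, no change shown marks a place where this assay responds.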